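The source may report more compounds than this note shows. Statements on the series, on what has been measured and on what is new or still open speak of the compounds shown alone.

Measured in a functional assay on FM3A cells (Mus musculus) for cytotoxicity; on this read-out higher numbers stand for an effect only at larger amounts of compound and lower numbers for an effect already at smaller amounts:
- compound 1 `CCCCOOC1(OOCCCC)CCCCCCCCCCC1` gives 8500 nM
- compound 2 `C=CCOOC1(OOCC=C)CCCCCCCCCCC1` gives 14000 nM
- compound 3 `COOC1(OOCCCc2ccccc2)CCCCCCCCCCC1` gives 34000 nM

Compound 3 has the highest number of the three, at 34000 nM. Its gap to compound 2 is the smaller one and its gap to compound 1 the larger, and both lie beyond the scatter. Compound 4 `COOC1(OOCCC(=O)O)CCCCCCCCCCC1` keeps the shared core and carries carboxy in place of benzyl on a saturated chain carbon, two bonds along the chain from an oxygen. Within the data shown here, no two measured compounds differ in one place, and none of them carries a carboxy group, so the data hold no direct measure of this change. Among the measured compounds shown here, the only guide is the spread of values in this assay, where compound 1 gives 8500 nM and compound 3 gives 34000 nM. A move towards a higher number is expected, of moderate size and beyond the scatter, though this remains uncertain. The estimated change is a 2.4-fold higher number from compound 3 to compound 4 (0.37 log units; beyond the scatter). For compound 4 the expected value is 80000 nM, within an estimated range from 25000 nM to 250000 nM.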

Compound 4, half-maximal effective concentration: 450 nM
Compound 4: middle estimate off by 180-fold (2.25 log units), on the high side; the whole stated range lies above it.
By their numbers in this assay, from the lowest: compound 4; then compounds 1 and 2 (each within the scatter of the next); then compound 3.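

In this assay, among these compounds, the first step between compounds that differ in one place is large: carboxy in place of benzyl, on a saturated chain carbon, two bonds along the chain from an oxygen, gives a 76-fold lower number from compound 3 to compound 4 (1.88 log units; beyond the scatter) and lies well beyond the scatter. This position therefore strongly affects the read-out, and the benzyl group with its aromatic ring is not needed for an effect at smaller amounts of compound. No measurement at hand accounts for the size of this step.

As far as these compounds go, it remains open whether the step comes from the carboxy group itself or from the loss of benzyl, which a methyl ester or a plain ethyl group at this place would help to separate. A longer chain ending in a carboxylic acid also remains an open case.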